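Hydroxy Replaces Chloro on a Weak Aryl Urea Series

A few compounds are considered here, and "the series" means these few. Any claim that something is new, unique, unknown or untested is made for them only; others in the source may bear on it.

Measured compounds and their values:
Compound 1, `COc1cc(NC(C)CCCNC(=O)NNC(=O)Nc2cccc(Cl)c2)c2ncccc2c1`, gives 32000 nM
Compound 2, `COc1cc(NC(C)CCCNC(=O)Nc2cccc(F)c2)c2ncccc2c1`, gives 24000 nM
Compound 3, `COc1cc(NC(C)CCCNC(=O)Nc2cccc(Cl)c2)c2ncccc2c1`, gives 37000 nM

All three share one core and are weak in a functional assay on NCI-H460 cells (Homo sapiens) for inhibition, read by MTT assay, with a stated time of 72 h; a lower number here means a stronger inhibitor, a higher number a weaker inhibitor. Compound 3 has the largest number written down here, yet nothing separates it from its neighbours beyond the usual scatter: the steps are a 1.2-fold higher number from compound 1 to compound 3 (0.06 log units; within the scatter) and a 1.5-fold higher number from compound 2 to compound 3 (0.19 log units; within the scatter).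

Compound 4, `COc1cc(NC(C)CCCNC(=O)Nc2cccc(O)c2)c2ncccc2c1`, is not yet measured. It differs from compound 3 by hydroxy in place of chloro on an aromatic carbon.

Among the compounds with values here, only one measured step touches the same aromatic carbon: a 1.5-fold higher number from compound 2 to compound 3 (0.19 log units; within the scatter), where one halogen replaced another and the number barely moved. Within the data shown here, no measured pair shows what a hydroxy group does at that position, so the change from compound 3 to compound 4 is new ground. With three weak compounds clustered closely together and no sign that this part of the molecule drives the number, the expectation is a step of a 1.1-fold lower number from compound 3 to compound 4 (0.02 log units; within the scatter), that is, no change beyond the scatter.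

Compound 4 is therefore estimated to give 35000 nM, within a range from 15000 nM to 80000 nM.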

Compound 4, half-maximal inhibitory concentration: 25000 nM
Estimate against measurement, compound 4: 1.4-fold (0.15 log units) above; the measured number falls inside the stated range.
By their numbers in this assay, from the lowest: compounds 2, 4, 1 and 3 (each within the scatter of the next).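

Measured in this assay, hydroxy on the aromatic carbon that holds chloro in compound 3 gives a small step (a 1.5-fold lower number from compound 3 to compound 4 (0.17 log units; within the scatter)), and its step from the fluoro analogue is smaller still (a 1.0-fold higher number from compound 2 to compound 4 (0.02 log units; within the scatter)), so chloro, fluoro and hydroxy cannot be told apart at this position. The earlier comparison here only exchanged one halogen for another, whereas hydroxy brings 1 hydrogen-bond donor and 1 hydrogen-bond acceptor where chloro has neither, and the number still stays within the scatter. Exchanging the whole ((3-chlorophenyl)carbamoyl)amino end of compound 1 for 3-hydroxyphenyl also leaves the number within the scatter (a 1.3-fold lower number from compound 1 to compound 4 (0.11 log units; within the scatter)), and nothing available offers a reason for this flat picture.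

From the compounds shown here alone, whether an amine or a carboxylic acid on this aromatic carbon would move the number beyond the scatter remains open. It is equally open whether a longer chain between the shared core and the urea would do so, as all four compounds shown lie close together in the weak range.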